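The source may report more compounds than this note shows. Statements on the series, on what has been measured and on what is new or still open speak of the compounds shown alone.

In a functional assay on SK-MEL-28 cells (Homo sapiens) for inhibition, read by MTT assay, with a stated time of 48 h (on this read-out lower numbers stand for stronger inhibition and higher numbers for weaker inhibition), compound 2 `C(=C/c1nc2ccccn2c1Sc1ccccc1)\c1ccccc1` gives 65400 nM and compound 3 `CS(=O)(=O)c1ccc(-c2nc3ccccn3c2Sc2cccc3ccccc23)cc1` gives 67300 nM as two values within the scatter of each other. Compound 1 `c1ccc(Sc2c(-c3cccc4ccccc34)nc3ccccn23)cc1` returns > 100000 nM in this assay and this reading is a limit and not a number. Among the compounds with values here, compound 2 thus holds one of only two true numbers so far.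

Compound 4 `c1ccc(Sc2c(-c3cccs3)nc3ccccn23)cc1` differs from compound 2 by thiophen-2-yl in place of 2-phenylethenyl on an aromatic carbon with thiophen-2-yl in place of 2-phenylethenyl on an aromatic carbon, next to the ring atom that bears a phenylsulfanyl group. Within the data shown here, no measured pair in this assay isolates this change, so its size is not fixed by the data. The expectation takes compound 2 at 65400 nM as its anchor. For compound 4 a reading at the limit of the assay remains possible. The step of a 1.1-fold higher number from compound 2 to compound 4 (0.03 log units; within the scatter) is expected to stay within the scatter, in neither direction. For compound 4 the estimated value is 70000 nM with an expected range from 30000 nM to 100000 nM for the coming measurement.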

Compound 4, half-maximal inhibitory concentration: 85300 nM
The estimate for compound 4 lay 1.2-fold (0.09 log units) below the measured number; the measured number falls inside the stated range.
By their numbers in this assay, from the lowest: compounds 2, 3 and 4 (each within the scatter of the next). At a limit, above all of these: compound 1.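

In this assay, the series now has its first step that isolates this position, the aromatic carbon next to the ring atom that bears a phenylsulfanyl group: a 1.3-fold higher number from compound 2 to compound 4 (0.12 log units; within the scatter). Thiophen-2-yl and 2-phenylethenyl differ in ring type, in heavy-atom count and in the double bond outside aromatic rings, yet this assay does not tell the two groups apart. Compound 1, which carries a different group on the same carbon, remains a limit and not a number, so it adds no step here: the limit of > 100000 nM in this assay, at which 1 of the 4 values shown sits.

Still open, on these data alone, is whether a group of another kind on this carbon, such as an amine, a carboxylic acid or a longer chain, would move the number beyond the scatter. As far as these compounds go, the effect of replacing the phenylsulfanyl group while keeping thiophen-2-yl in place is also open.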